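Methoxy to Ethoxy on an Aryl Amide, Taken Twice

The source may hold more compounds than are shown below. What is called first, only, known or untested is meant among the compounds shown, and "the series" means these compounds.

Of the compounds shown here, three built on one shared core have been measured, and a fourth awaits its number. Compound 1 `COc1cccc(NC(=O)C2Cc3cc(OC)c(OC)cc3C2=O)c1` gives 2.08 in a physicochemical assay for lipophilicity, read by mass spectrometry; on this read-out lower numbers stand for lower lipophilicity and higher numbers for higher lipophilicity. Compound 2 `CCOc1cccc(NC(=O)C2Cc3cc(OC)c(OC)cc3C2=O)c1` carries the change (methyl in place of hydrogen on a saturated chain carbon bound to an oxygen on an aromatic ring), and in this assay compound 2 gives 2.42, so that a number 0.34 log units higher from compound 1 to compound 2 (beyond the scatter). Compound 3 `COc1ccccc1NC(=O)C1Cc2cc(OC)c(OC)cc2C1=O` differs from compound 1 by 2-methoxyphenyl in place of 3-methoxyphenyl on an amide-type nitrogen; in this assay compound 3 gives 2.08, and no change at the digits printed from compound 1 to compound 3 (within the scatter), which leaves compound 3 and compound 1 together at the lowest level of the three numbers. Compound 4 `CCOc1ccccc1NC(=O)C1Cc2cc(OC)c(OC)cc2C1=O` has not yet been measured. It differs from compound 3 by methyl in place of hydrogen on a saturated chain carbon bound to an oxygen on an aromatic ring, which is the same change as the one between the first two compounds, with the place described in identical words. For compound 4 the expected step is a number 0.34 log units higher from compound 3 to compound 4 (beyond the scatter), an expectation that rests on a single earlier example, because a number 0.34 log units higher from compound 1 to compound 2 (beyond the scatter). In this assay compound 4 is therefore estimated at 2.42, expected to fall between 2.12 and 2.72.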

Compound 4, partition coefficient: 2.42
Compound 4: the middle estimate sits on the measured number at the digits printed, and the stated range covers the measured number.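

Going from methoxy to ethoxy gave a number 0.34 log units higher from compound 3 to compound 4 (beyond the scatter) in this assay, and the same change gave a number 0.34 log units higher from compound 1 to compound 2 (beyond the scatter), so the step has the same size in two compounds that differ by 2-methoxyphenyl in place of 3-methoxyphenyl on the amide-type nitrogen. Going by these compounds alone, these are only two examples, which makes the change transferable between this one pair of close relatives but does not show that it would carry over to a different core, or to a different place on this one. Nothing available here explains why the step has this size.

The compounds shown leave open what a longer chain, such as propoxy in place of ethoxy, would do to the number in this series. They also leave open whether a chain ending in an amine or a carboxylic acid would follow the same pattern, or break from it.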